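Nitro in place of dimethylcarbamoyl on the shared core

The source may report more compounds than this note shows. Statements on the series, on what has been measured and on what is new or still open speak of the compounds shown alone.

Compound 1 `Nc1nc2ccnc(-c3cccc(C(F)(F)F)c3)n2n1`: 2200 nM; 2200 nM (2 entries)
Compound 2 `Cc1cccc(-c2nccc3nc(N)nn23)c1`: 5500 nM
Compound 3 `CN(C)C(=O)c1cccc(-c2nccc3nc(N)nn23)c1`: 3500 nM

In a functional assay (Homo sapiens) (a lower number here means a stronger inhibitor, a higher number a weaker inhibitor), compound 3 gives 3500 nM, which stands within the scatter of compound 2. Next is compound 4 `Nc1nc2ccnc(-c3cccc([N+](=O)[O-])c3)n2n1`, with nitro in place of dimethylcarbamoyl on an aromatic carbon, meta to a large group: nitro in place of dimethylcarbamoyl on an aromatic carbon. Within the data shown here, only one measured step bears on this change, and it also involves dimethylcarbamoyl: a 1.6-fold lower number from compound 2 to compound 3 (0.20 log units; within the scatter). Among the measured compounds shown here, with so small a step as the sole guide, no change beyond the scatter is expected in this assay, though a single step is thin evidence. The expected step is a 1.2-fold lower number from compound 3 to compound 4 (0.07 log units; within the scatter). For compound 4 the estimated value is 3000 nM, with an expected range of 1100 nM to 8000 nM.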

Compound 4, half-maximal inhibitory concentration: 3800 nM
Compound 4: the middle estimate sits 1.3-fold (0.10 log units) below what was measured, and the stated range covers the measured number.
By their numbers in this assay, from the lowest: compounds 3, 4 and 2 (each within the scatter of the next).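

In this assay nitro on this aromatic carbon gives a 1.1-fold higher number from compound 3 to compound 4 (0.04 log units; within the scatter) and, against methyl, a 1.4-fold lower number from compound 2 to compound 4 (0.16 log units; within the scatter) so both steps stay small. Methyl, dimethylcarbamoyl and nitro at this place therefore cannot be told apart in this assay even though they differ in size and in hydrogen-bond acceptors. No measurement at hand accounts for this flat result. Going by these compounds, whether an amine, a carboxylic acid or a longer chain at this place would move the number beyond the scatter remains open. So does whether another place on the shared core responds more strongly.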